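Swapping a thiazole for an imidazole on the tetrazole core

This account rests on a few compounds, and the source may have more. Where it says the series, first, only, none or still open, it means among the compounds named here.

Measured compounds:
- Compound 1 `Cc1c[nH]c(-c2nnn(-c3cc(F)cc(C#N)c3)n2)n1`: 19 nM
- Compound 2 `N#Cc1cccc(-n2nnc(-c3ncc[nH]3)n2)c1`: 34 nM
- Compound 3 `N#Cc1cccc(-n2nnc(-c3cscn3)n2)c1`: 157 nM

In an assay for binding affinity to metabotropic glutamate receptor 5 (Rattus norvegicus) (on this read-out higher numbers stand for weaker inhibition and lower numbers for stronger inhibition), compound 3 gives the highest of the three numbers, so it is the weakest binder here. Its nearest neighbour in the series is compound 2, which shares the same core and differs only in the five-membered ring attached to it; the measured step of a 4.6-fold higher number from compound 2 to compound 3 (0.66 log units; beyond the scatter) shows that replacing the imidazole with a thiazole weakened binding by a modest but real amount. Compound 1, with an added methyl group and a fluorine, stands further away again.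

Compound 4 `N#Cc1cccc(-n2nnc(-c3c[nH]cn3)n2)c1` has not yet been measured. The change from compound 3 is 1H-imidazol-4-yl in place of 1,3-thiazol-4-yl on an aromatic carbon. For the measured compounds named here, it reverses the kind of swap seen in the step from compound 2 to compound 3, though the new imidazole is attached through a different ring carbon than in compound 2, so the earlier step is the only guide and may not carry over fully. On that basis a gain in binding, somewhat smaller than the earlier step, is expected: a 3.1-fold lower number from compound 3 to compound 4 (0.50 log units; beyond the scatter). Compound 4 is therefore estimated at 50 nM, with a plausible range of 18 nM to 150 nM.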

Compound 4, inhibition constant: > 2000 nM
Compound 4: only a limit was reported; the forecaster's own chance of this, stated with the estimate: 2%; middle value at least 40-fold (1.60 log units) from the limit.
By their numbers in this assay, from the lowest: compounds 1 and 2 (each within the scatter of the next); then compound 3. At a limit, above all of these: compound 4.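

The value for compound 4 is a limit of the assay, not a number: the limit of > 2000 nM in this assay, at which 1 of the 4 values shown sits. Even so, the step can be read, and an at least 12-fold higher number from compound 3 to compound 4 (1.10 log units; beyond the scatter) shows that at this position the 1H-imidazol-4-yl group binds far worse than the 1,3-thiazol-4-yl group, so the advantage of the imidazole in compound 2 does not carry over to every imidazole. Changing only the ring carbon through which the imidazole is attached gives an at least 58-fold higher number from compound 2 to compound 4 (1.76 log units; beyond the scatter), which shows that the point of attachment matters at least as much here as the choice of ring.

These values do not say what lies behind the loss. As far as these compounds go, how a 1,3-oxazol-4-yl ring or a 1H-pyrazol-3-yl ring would behave on this same carbon also remains open.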